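The source may hold more compounds than are shown below. What is called first, only, known or untested is meant among the compounds shown, and "the series" means these compounds.

In a functional assay on CHO cells (Cricetulus griseus) for cytotoxicity (a higher number here means a weaker inhibitor, a lower number a stronger inhibitor), compound 1 `CN(Cc1cnc2ncncc2n1)c1ccc(C(=O)N[C@@H](CCC(=O)O)C(=O)O)cc1` gives 350 nM. Among the measured compounds shown here, compound 2 `CN(Cc1cnc2ncncc2n1)c1ccc(C(=O)N[C@@H](CCC(=O)OCOC(=O)C(C)(C)C)C(=O)OCOC(=O)C(C)(C)C)cc1` stands level with it at 350 nM, so compound 1 sits with its only measured neighbour and the two values give no spread to work from. Compound 3 `CN(Cc1cnc2ncncc2n1)c1ccc(C(=O)N[C@@H](CCC(=O)NC(CCC(=O)O)C(=O)O)C(=O)O)cc1` keeps the core of compound 1 and differs at one place: (1,3-dicarboxypropyl)amino in place of hydroxy on a carbonyl carbon. For the measured compounds named here, no measured pair isolates this change, so its size rests on judgement alone. The entering group is much larger than the hydroxy it replaces, and a moderate move toward weaker inhibition in this assay is expected, though a result within the scatter would not surprise. The estimated change is a 2.3-fold higher number from compound 1 to compound 3 (0.36 log units; beyond the scatter). For compound 3 the expected value is 800 nM, with an estimated range of 200 nM to 4000 nM.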

Compound 3, half-maximal inhibitory concentration: 350 nM
Estimate against measurement, compound 3: 2.3-fold (0.36 log units) above; low and high end bracket the measured number.
By their numbers in this assay, from the lowest: compounds 1, 2 and 3 (each within the scatter of the next).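

In this assay, (1,3-dicarboxypropyl)amino in place of hydroxy on a carbonyl carbon gives no change at the digits printed from compound 1 to compound 3 (within the scatter). Among the compounds shown here, this is the first single-place step, and it shows that this position accepts an entering group much larger than the hydroxy it replaces, with its two extra carboxy groups, without a read-out change beyond the scatter. Nothing at hand explains this flat step.

From the compounds shown here alone, it remains open whether a plain amino group or a methoxy group at this carbonyl carbon would also leave the read-out within the scatter of compound 1. Going by these compounds, it is equally open whether a longer chain carrying further carboxy groups would do so, since one step gives size tolerance at a single point and no trend.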